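The compounds below may be only part of what the source reports. "The series", "measured", "known", "first", "only" and "open" are said of these compounds alone.

Measured so far:
Compound 1, `CC(C)(C)c1cc(NC(=O)Nc2cc(C(F)(F)F)cc(C(F)(F)F)c2)n(-c2ccccc2)n1`, gives -0.5 degrees C in an assay on isolated protein for inhibition of serine/threonine-protein kinase 10 (Homo sapiens), read by thermal shift assay, tested at 10 uM; on this read-out higher numbers stand for stronger stabilisation of the target against heat and lower numbers for weaker stabilisation of the target.
Compound 2, `Cc1ccc(-n2nc(C(C)(C)C)cc2NC(=O)Nc2cc(C(F)(F)F)cc(C(F)(F)F)c2)cc1`, gives -0.5 degrees C.
Compound 3, `CC(C)(C)c1cc(NC(=O)Nc2cc(F)cc(F)c2)n(-c2ccccc2)n1`, gives 2.5 degrees C.

Going by the values given here, the only single change measured here is methyl in place of hydrogen on an aromatic carbon, and it gave no change at the digits printed from compound 1 to compound 2 (within the scatter). Compound 3 stands highest of the three, and its value lies beyond the scatter from both compound 1 and compound 2. The difference between the core of compound 1 and the core of compound 3 is not broken down here.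

Compound 4, `Cc1ccc(-n2nc(C(C)(C)C)cc2NC(=O)Nc2cc(F)cc(F)c2)cc1`, has not yet been measured. It differs from compound 3 by methyl in place of hydrogen on an aromatic carbon, the same change as that between compound 1 and compound 2. Because no change at the digits printed from compound 1 to compound 2 (within the scatter) stayed within the scatter, a step of about no change at the digits printed from compound 3 to compound 4 (within the scatter) is expected here too. Compound 4 is therefore estimated to give 2.5 degrees C, with a likely range from 1 degrees C to 4 degrees C.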

Compound 4, shift of the target's melting temperature: 0.6 degrees C
Estimate against measurement, compound 4: 1.9 degrees C above, and the stated range ends above it.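

In this assay, replacing phenyl with 4-methylphenyl gives a number 1.9 degrees C lower from compound 3 to compound 4 (beyond the scatter). The step therefore does not carry over unchanged between these two cores: the same change on two cores in this assay, no change at the digits printed (within the scatter) from compound 1 to compound 2 and a number 1.9 degrees C lower (beyond the scatter) from compound 3 to compound 4, 1.9 degrees C apart, beyond the scatter of two such steps. These two pairs do not show why the cores differ, or how the same change would behave on a third core.

The compounds shown leave open what other groups would do in the same place on the phenyl ring, such as a chlorine, a methoxy group or an amine. They also leave open whether a longer chain there, such as an ethyl group, would behave as the methyl does on the core of compound 1 or on that of compound 3.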